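Removing One Methoxy Group: What to Expect for Compound 3

The compounds below may be only part of what the source reports. "The series", "measured", "known", "first", "only" and "open" are said of these compounds alone.

Measured so far:
compound 1, `COc1ccc(CNc2nc3cc(N)cc(N)c3nc2-c2ccccc2)cc1OC`: < 100000 nM
compound 2, `COc1cc(CNc2nc3cc(N)cc(N)c3nc2-c2ccccc2)cc(OC)c1OC`: 36300 nM

Two compounds share a common core and differ only in the substitution of the pendant benzyl ring. In a functional assay on SK-OV-3 cells (Homo sapiens) for inhibition, read by sulforhodamine B assay, with a stated time of 48 h (a lower number here means that less compound is tolerated, a higher number that more compound is tolerated), compound 1 gives < 100000 nM, and this is a limit of the assay, not a number. Compound 2 carries one additional methoxy group on an aromatic carbon, and in this assay compound 2 gives 36300 nM. The step between them, a step that the limit leaves unreadable from compound 1 to compound 2, has no readable size because of the limit of < 100000 nM in this assay, at which 1 of the 2 values shown sits.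

Compound 3, `COc1ccc(CNc2nc3cc(N)cc(N)c3nc2-c2ccccc2)cc1`, goes the other way from compound 1: the change is hydrogen in place of methoxy on an aromatic carbon, that is, 3,4-dimethoxyphenyl becomes 4-methoxyphenyl. Going by the values given here, the single measured step bears on this change only loosely, since it concerns the addition of a methoxy group and its size is unreadable. With compound 1 itself known only as a limit, no direction beyond the scatter can be claimed for the step in this assay.

Compound 3 is therefore expected to give about 50000 nM, with a range from 15000 nM to 120000 nM, which corresponds to an expected step that the limit leaves unreadable from compound 1 to compound 3.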

Compound 3, concentration lethal to 50% of the cells: < 100000 nM
Compound 3: no number, only a limit; the forecaster's own chance of this, stated with the estimate: 35%; the middle value lies beyond the limit too.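

No step can be read between compound 1 and compound 3, since each is known only as a limit of the assay and not as a number: the limit of < 100000 nM in this assay, at which 2 of the 3 values shown sit.

In this assay the compounds shown leave open whether going from 3,4-dimethoxyphenyl to 4-methoxyphenyl changes the value at all, and in which direction.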